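The compounds below may be only part of what the source reports. "The series", "measured", "known", "first", "only" and "open" are said of these compounds alone.

The measured compounds are:
compound 1 `Cc1ccc(-c2nn(-c3ccccc3)cc2C(=O)NOCc2ccccc2)cc1` with 1140 nM;
compound 2 `Cc1ccc(-c2nn(-c3ccccc3)cc2C(=O)NOCc2ccccc2F)cc1` with 260 nM;
compound 3 `O=C(NOCc1ccccc1)c1cn(-c2ccccc2)nc1-c1ccc(Cl)cc1` with 13000 nM.

All three were tested in a functional assay on A549 cells (Homo sapiens) for antiproliferative activity, read by MTT assay, with a stated time of 48 h, in the presence of a further agent that is not named here; on this read-out lower numbers stand for stronger inhibition of growth and higher numbers for weaker inhibition of growth. Compound 2 differs from compound 1 by a single change, (fluoro in place of hydrogen on an aromatic carbon), and this change brought a 4.4-fold lower number from compound 1 to compound 2 (0.64 log units; beyond the scatter). Compound 3 differs from compound 1 in its core by chloro in place of methyl on an aromatic carbon, and this change brought an 11-fold higher number from compound 1 to compound 3 (1.06 log units; beyond the scatter), so that compound 3 stands with the highest number of the three, with compound 2 the furthest from it.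

Compound 4 `O=C(NOCc1ccccc1F)c1cn(-c2ccccc2)nc1-c1ccc(Cl)cc1` has not yet been measured in this assay. It differs from compound 3 by fluoro in place of hydrogen on an aromatic carbon. This is the same change as that from compound 1 to compound 2, made here on the core of compound 3 rather than on the core of compound 1. Whether the change has the same effect on the second core cannot be read from the compounds shown, since it has been measured on one core only.

In this assay compound 4 is expected to give about 3500 nM, with a range from 1200 nM to 10000 nM. This estimate means an expected step of a 3.7-fold lower number from compound 3 to compound 4 (0.57 log units; beyond the scatter). Among the measured compounds shown here, that expectation rests on a 4.4-fold lower number from compound 1 to compound 2 (0.64 log units; beyond the scatter), the single measurement of this change, and on the starting point set by compound 3 at 13000 nM, with the range widened to allow for the change behaving differently on the second core.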

Compound 4, concentration for 50% growth inhibition: 12100 nM
Compound 4: middle estimate off by 3.5-fold (0.54 log units), on the low side, and the stated range ends below it.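

In this assay, fluoro in place of hydrogen on the benzyl group gave a 1.1-fold lower number from compound 3 to compound 4 (0.03 log units; within the scatter), so the clear shift seen on the core of compound 1 did not carry over to the core of compound 3: the same change on two cores in this assay, a 4.4-fold lower number (0.64 log units; beyond the scatter) from compound 1 to compound 2 and a 1.1-fold lower number (0.03 log units; within the scatter) from compound 3 to compound 4, 4.1-fold (0.61 log units) apart, beyond the scatter of two such steps. Read from the other side, chloro in place of methyl gave a 47-fold higher number from compound 2 to compound 4 (1.67 log units; beyond the scatter), a larger step with the 2-fluorobenzyl group in place than with the plain benzyl group: the same change on two cores in this assay, an 11-fold higher number (1.06 log units; beyond the scatter) from compound 1 to compound 3 and a 47-fold higher number (1.67 log units; beyond the scatter) from compound 2 to compound 4, 4.1-fold (0.61 log units) apart, beyond the scatter of two such steps. Both comparisons rest on the same four compounds and are therefore one observation: in this set the two changes do not act independently of each other, so a step measured on one core could not be carried to the other, but this does not show why they interact or whether the same holds for any other core or group.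

The compounds shown leave open whether a methoxy group or a bromine atom in place of the methyl or chloro would follow compound 1 or compound 3 in its response to the 2-fluorobenzyl group. They also leave open whether a chlorine atom or a methyl group in place of the fluoro on the benzyl group would depend on the core in the same way.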